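The compounds below may be only part of what the source reports. "The series", "measured", "known", "first", "only" and "open" are said of these compounds alone.

Compound 1 `N#Cc1ncc2nc1OCC/C=C\COc1ccc(CCCO)cc1NC(=O)N2` and compound 2 `N#Cc1ncc2nc1OCC/C=C\COc1ccc(OCCO)cc1NC(=O)N2` share one core, and compound 3 `N#Cc1ncc2nc1OCCCCCOc1ccc(CCCO)cc1NC(=O)N2` carries the other; the difference between the two cores is not broken down here. In a functional assay on NCI-H1299 cells (Homo sapiens), read by flow cytometry (a higher number here means that more compound is needed for the effect, a lower number that less compound is needed), compound 1 gives only a limit, > 10000 nM. In this assay compound 2 likewise gives only a limit, > 10000 nM. The change from compound 1 to compound 2 is 2-hydroxyethoxy in place of 3-hydroxypropyl on an aromatic carbon, and the step it made, a step that the two limits leave unreadable from compound 1 to compound 2, cannot be sized. Compound 3 also gives only a limit in this assay, > 10000 nM. All three values share (the limit of > 10000 nM in this assay, at which 3 of the 3 values shown sit). Compound 4 `N#Cc1ncc2nc1OCCCCCOc1ccc(OCCO)cc1NC(=O)N2` differs from compound 3 by 2-hydroxyethoxy in place of 3-hydroxypropyl on an aromatic carbon, the same change. Because compound 3 sits at > 10000 nM and the step that the two limits leave unreadable from compound 1 to compound 2 is unreadable, the step to compound 4 is expected to be a step that the limit leaves unreadable from compound 3 to compound 4. Compound 4 is expected to give 20000 nM, most likely again a limit.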

Compound 4, half-maximal effective concentration: > 10000 nM
Compound 4 was reported as a limit; the forecaster's own chance of this, stated with the estimate: 90%; the middle value is on the limit's open side.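

In this assay, for the compounds shown here, compound 4 gives only a limit, > 10000 nM, so no step from compound 3 to compound 4 can be read. The compounds shown leave open how their cores and side chains would rank, as all rest on one value: the limit of > 10000 nM in this assay, at which 4 of the 4 values shown sit.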